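This account rests on a few compounds, and the source may have more. Where it says the series, first, only, none or still open, it means among the compounds named here.

Compound 1 `COc1ccc2c(=O)c(/C=C/C(=O)Nc3ccccc3OC)coc2c1`: 32300 nM
Compound 2 `COc1ccc2c(=O)c(/C=C/C(=O)NCc3ccc(F)cc3F)coc2c1`: > 100000 nM

In a functional assay on Huh-7 cells (Homo sapiens) for inhibition, read by MTT assay, with a stated time of 48 h (on this read-out lower numbers stand for stronger inhibition and higher numbers for weaker inhibition), compound 1 gives 32300 nM. For compound 2 this assay reports only a limit, > 100000 nM, and not a number, so compound 2 stands at the edge of what was measured (the limit of > 100000 nM in this assay, at which 1 of the 2 values shown sits). For the measured compounds named here, the single measured step, an at least 3.0-fold higher number from compound 1 to compound 2 (0.49 log units; beyond the scatter), therefore marks a loss of potency whose full size is not known.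

Compound 3 `CCOc1ccc(NC(=O)/C=C/c2coc3cc(OC)ccc3c2=O)cc1` differs from compound 2 by 4-ethoxyphenyl in place of 2,4-difluorobenzyl on an amide-type nitrogen. Going by the values given here, the one measured step that bears on this change is the one just named, which replaced an aryl group on the amide nitrogen by a benzyl group and weakened inhibition. Among the compounds with values here, compound 3 goes back to an aryl group on that nitrogen, as in compound 1, though with a 4-ethoxyphenyl rather than a 2-methoxyphenyl group, a change for which no measured step exists. Compound 3 is therefore expected to move back toward the value of compound 1, by a step of about an at least 2.5-fold lower number from compound 2 to compound 3 (0.39 log units; beyond the scatter). The estimate for compound 3 in this assay is 40000 nM, with a range from 15000 nM to 120000 nM.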

Compound 3, half-maximal inhibitory concentration: 3230 nM
Compound 3: the middle estimate sits 12-fold (1.09 log units) above what was measured, outside the stated range (below it).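

The 4-ethoxyphenyl result shows that on this amide-type nitrogen the choice of aryl group itself matters, which the earlier pair could not show: 4-ethoxyphenyl in place of 2-methoxyphenyl gives a 10-fold lower number from compound 1 to compound 3 (1.00 log units; beyond the scatter) in this assay. The earlier compounds shown here showed only a loss at this position, whereas this change gives a gain, and the comparison with the 2,4-difluorobenzyl group gives an at least 30-fold lower number from compound 2 to compound 3 (1.49 log units; beyond the scatter), so the position spans a much wider range of values than the first step revealed. The full size of that last step remains unknown, as compound 2 has only a limit and not a number, > 100000 nM: the limit of > 100000 nM in this assay, at which 1 of the 3 values shown sits.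

The compounds shown do not tell whether the gain with 4-ethoxyphenyl rests on the ethoxy group or on the phenyl ring that carries it. Nor do they tell how a longer chain such as propoxy, or an amine or a carboxylic acid in place of the ethoxy group, would read in this assay.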